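From a carboxy group to a silicon-bearing group

The compounds below may be only part of what the source reports. "The series", "measured", "known", "first", "only" and "open" are said of these compounds alone.

Measured so far in a functional assay on MCF7 cells (Homo sapiens) for antiproliferative activity, read by MTT assay, with a stated time of 48 h; a lower number here means a stronger inhibitor, a higher number a weaker inhibitor
- compound 1 `COC/C1=C/C[C@](C)(CCC=C(C)C)/C=C/[C@@H](OC(=O)C=C(C)C)[C@](C)(OC)/C=C/C1=O`: 16500 nM
- compound 2 `CC(C)=CCC[C@]1(C)/C=C/[C@@H](OC(=O)C=C(C)C)[C@](C)(O)/C=C/C(=O)/C(C(=O)O)=C\C1`: 16100 nM

Compound 2 gives 16100 nM and stands level with compound 1, the two values lying within the scatter. Compound 3 `CC[Si](CC)(CC)C/C1=C/C[C@](C)(CCC=C(C)C)/C=C/[C@@H](OC(=O)C=C(C)C)[C@](C)(O)/C=C/C1=O` carries, on a double-bonded ring carbon, a group of 8 heavy atoms (7 carbon, 1 silicon; no ring) in place of the carboxy group of compound 2 (a group of 8 heavy atoms (7 carbon, 1 silicon; no ring) in place of a group of 3 heavy atoms (1 carbon, 2 oxygen; no ring), on a double-bonded ring carbon). For the measured compounds named here, no measured pair shows this change alone. The expectation in this assay is therefore no step beyond the scatter in either direction, and the estimated step is small (a 1.3-fold lower number from compound 2 to compound 3 (0.13 log units; within the scatter)). For compound 3 the estimate is 12000 nM (expected range 4000 nM to 35000 nM).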

Compound 3, half-maximal inhibitory concentration: 3150 nM
Estimate against measurement, compound 3: 3.8-fold (0.58 log units) above; measured number below the stated range.
By their numbers in this assay, from the lowest: compound 3; then compounds 2 and 1 (each within the scatter of the next).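

In this assay, the double-bonded ring carbon proves sensitive to what it carries: the silicon-bearing group in place of the carboxy group brings a 5.1-fold lower number from compound 2 to compound 3 (0.71 log units; beyond the scatter). Compound 1 and compound 2 stood level and differ in more than one place, so they could not show this. Nothing measured here accounts for the step. Still open is whether the silicon itself matters, since a matching chain with carbon in its place is not among the compounds shown. On these data alone, how an amine or a shorter trimethylsilyl group would fare at this carbon also remains open.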